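Aryl ether series: removing the fluorine of compound 2

The compounds below may be only part of what the source reports. "The series", "measured", "known", "first", "only" and "open" are said of these compounds alone.

Going by the values given here, compound 2 `Fc1ccc(Oc2ccnc(N3CCC(NC(=S)Nc4cccnc4)CC3)c2)cc1` gives 1400 nM in an assay on membranes from brain for binding affinity to Lysophosphatidylserine lipase ABHD12 (Mus musculus), read by fluorescence, with a stated time of 20 min (on this read-out lower numbers stand for stronger inhibition and higher numbers for weaker inhibition), the only number reported in this pair so far. Compound 1 `COc1ccnc(N2CCC(NC(=S)Nc3cccnc3)CC2)c1` sits at the assay limit > 5000 nM in this assay, a limit rather than a number. Among the compounds with values here, the single measured step, an at least 3.5-fold lower number from compound 1 to compound 2 (0.55 log units; beyond the scatter), concerns the whole oxygen substituent, so no measured step addresses the fluoro on its own. Compound 3 `S=C(Nc1cccnc1)NC1CCN(c2cc(Oc3ccccc3)ccn2)CC1` differs from compound 2 by hydrogen in place of fluoro on an aromatic carbon. Within the data shown here, with no step resolving this place, no change beyond the scatter is expected in this assay. Compound 3 is estimated at 1800 nM, with a range from 700 nM to 5000 nM. The expected step is a 1.3-fold higher number from compound 2 to compound 3 (0.11 log units; within the scatter).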

Compound 3, half-maximal inhibitory concentration: 1900 nM
Beside the measured number, compound 3's estimate is 1.1-fold (0.02 log units) below it; low and high end bracket the measured number.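

Swapping the fluoro for hydrogen leaves the number within the scatter, a 1.4-fold higher number from compound 2 to compound 3 (0.13 log units; within the scatter), so the fluoro is not required at this position. The phenyl alone, without the fluoro, still carries a change beyond the scatter relative to the methyl on the oxygen, an at least 2.6-fold lower number from compound 1 to compound 3 (0.42 log units; beyond the scatter). Compound 1 gives > 5000 nM, a limit and not a number, so the full size of that step stays undefined.

Going by these compounds, whether an amine or a carboxylic acid on this phenyl would shift the number beyond the scatter remains open. So does the effect of a longer chain between the oxygen and the phenyl.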